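Neopentyl for tert-Butoxycarbonyl in a Metabolically Stable Pair

The source may report more compounds than this note shows. Statements on the series, on what has been measured and on what is new or still open speak of the compounds shown alone.

Within the data shown here, compound 2 `CC(C)(C)OC(=O)NCCS(=O)(=O)NC(=O)c1ccc(Nc2nc(NC3(c4ccc(Cl)cc4)CC3)nc(OCC(F)(F)F)n2)cc1` stands within the scatter of the only other compound measured: in an ADME assay on microsomes from liver (Homo sapiens) for metabolic stability, with a stated time of 10 min (a higher number here means that more of the compound is left, a lower number that less of the compound is left), compound 2 gives 92%, while compound 1 `CC(C)S(=O)(=O)NC(=O)c1ccc(Nc2nc(NC3(c4ccc(Cl)cc4)CC3)nc(OCC(F)(F)F)n2)cc1` gives 100%, and the step of a number 8 percentage points lower from compound 1 to compound 2 (within the scatter) is within the scatter. Compound 3 `CC(C)(C)CNCCS(=O)(=O)NC(=O)c1ccc(Nc2nc(NC3(c4ccc(Cl)cc4)CC3)nc(OCC(F)(F)F)n2)cc1` differs from compound 2 by neopentyl in place of tert-butoxycarbonyl on an amine nitrogen. Among the measured compounds shown here, the one measured step concerns a different place, the sulfonyl sulfur, and was small, so no step bears directly on the amine nitrogen. A step of a number 7 percentage points lower from compound 2 to compound 3 (within the scatter) is therefore expected, none beyond the scatter. Compound 3 is estimated at 85%, between 60% and 100%.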

Compound 3, percent of the compound remaining: 89%
The estimate for compound 3 lay 4 percentage points below the measured number; the range from low to high includes it.
By their numbers in this assay, from the lowest: compounds 3, 2 and 1 (each within the scatter of the next, the first and the last beyond it).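

In this assay, among these compounds, neopentyl in place of tert-butoxycarbonyl on an amine nitrogen gives a number 3 percentage points lower from compound 2 to compound 3 (within the scatter), so the two compounds cannot be told apart, and this is the first reading at that nitrogen. Among the compounds shown here, with 2-(neopentylamino)ethyl in place of isopropyl on a sulfonyl sulfur, the result is a number 11 percentage points lower from compound 1 to compound 3 (beyond the scatter), the first step here to pass the scatter, though only modestly. Nothing available explains either step. From the compounds shown here alone, how the unsubstituted amine, an acetyl group or a longer chain on that nitrogen would read remains open.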